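The source may hold more compounds than are shown below. What is called first, only, known or untested is meant among the compounds shown, and "the series" means these compounds.

Measured in a physicochemical assay for lipophilicity, using the shake flask method; a lower number here means a more polar compound, a higher number a more lipophilic compound:
- compound 1 `N/N=C/c1c(N)ncnc1Oc1ccc(NC(=O)C2(C(=O)Nc3ccc(F)cc3)CC2)cc1F` gives 2.25
- compound 2 `Nc1ncnc(Oc2ccc(NC(=O)C3(C(=O)Nc4ccc(F)cc4)CC3)cc2F)c1/C=N/OCC(=O)N1CCOCC1` gives 2.1

Among the measured compounds shown here, the only measured step is a number 0.15 log units lower from compound 1 to compound 2 (within the scatter), so compound 2 and compound 1 cannot be told apart on these numbers.

Compound 3 `CCCCO/N=C/c1c(N)ncnc1Oc1ccc(NC(=O)C2(C(=O)Nc3ccc(F)cc3)CC2)cc1F` differs from compound 2 in one place: propyl in place of (morpholin-4-yl)carbonyl on a saturated chain carbon bound to an oxygen. Cut one bond further out, the same difference reads ((morpholin-4-yl)carbonyl)methoxy to butoxy.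

The measured step bears on this only in part. It shows that compound 2, with the group now leaving, sits at 2.1, within the scatter of compound 1. It says nothing about a butoxy chain, since neither measured compound carries one, and so its small size is no guide here. The expectation rests mainly on the counted change: a ring and its hydrogen-bond acceptors go, and a plain carbon chain comes in. In this assay a move towards the more lipophilic end is therefore expected.

The expected step, beyond the scatter, is a number 1.40 log units higher from compound 2 to compound 3 (beyond the scatter). For compound 3 the estimate is 3.5, with an expected range from 2.8 to 4.2.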

Compound 3, partition coefficient: 4.2
Beside the measured number, compound 3's estimate is 0.70 log units below it, within the range that was stated.
By their numbers in this assay, from the lowest: compounds 2 and 1 (each within the scatter of the next); then compound 3.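

In this assay, the earlier pair gave no sign that the group on the double-bonded nitrogen matters, since those two compounds could not be told apart. The butoxy chain changes that picture: the number rises by a number 2.10 log units higher from compound 2 to compound 3 (beyond the scatter), and the step of a number 1.95 log units higher from compound 1 to compound 3 (beyond the scatter) is likewise large and beyond the scatter, so this position can shift the read-out strongly and compound 3 stands clearly apart from both earlier compounds. Why the number climbs this far is not explained by any supporting measurement available here.

The step from compound 2 to compound 3 also removes the morpholine ring and the carbonyl while bringing in the plain chain, so these compounds cannot show how much of the rise belongs to each part. Still open, on these data alone, is where a shorter chain such as ethoxy, a longer one such as hexyloxy, or a butoxy chain ending in an amine or a carboxylic acid would fall on this scale.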